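This account rests on a few compounds, and the source may have more. Where it says the series, first, only, none or still open, it means among the compounds named here.

Measured so far in a functional assay on K562 cells (Homo sapiens) for antiproliferative activity, read by CellTiter-Glo and CCK-8 assay, with a stated time of 72 h; a higher number here means a weaker inhibitor of growth, a lower number a stronger inhibitor of growth:

- compound 1 `CNc1nc(Nc2ccc(C)c([N+](=O)[O-])c2)ncc1C(=O)Nc1cc(NC(=O)c2ccccc2OC)ccc1C`; in this assay compound 1 gives > 10000 nM, which is a limit of the assay and not a number.
- compound 2 `CNc1nc(Nc2ccc(C)c([N+](=O)[O-])c2)ncc1C(=O)Nc1cc(NC(=O)c2ccc(OC)cc2)ccc1C`; in this assay compound 2 gives 1530 nM.

Compound 2 holds the only number shown in this assay; the other value shown is a limit, as noted under (the limit of > 10000 nM in this assay, at which 1 of the 2 values shown sits). Going by the values given here, the one measured step, an at least 6.5-fold lower number from compound 1 to compound 2 (0.81 log units; beyond the scatter), moved the methoxy on the carbonyl-bearing ring from one position to another, and its size is only known as a lower bound since compound 1 sits at the limit.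

Compound 3 `CNc1nc(Nc2ccc(C)c([N+](=O)[O-])c2)ncc1C(=O)Nc1cc(NC(=O)c2ccc(OC)c(OC)c2)ccc1C` differs from compound 2 by methoxy in place of hydrogen on an aromatic carbon, ortho to a methoxy group and meta to a large group. Among the compounds with values here, no measured step adds a substituent to this ring; the step from compound 1 to compound 2 bears on it only in showing that this ring tolerates change. The expectation for compound 3 is therefore a step of a 1.0-fold lower number from compound 2 to compound 3 (0.01 log units; within the scatter) in this assay, not beyond the scatter in either direction. Compound 3 is expected at 1500 nM, within 500 nM to 4500 nM.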

Compound 3, concentration for 50% growth inhibition: 680 nM
Estimate against measurement, compound 3: 2.2-fold (0.34 log units) above; the measured number falls inside the stated range.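

In this assay, adding a substituent to this ring changes the number beyond the scatter, with a 2.3-fold lower number from compound 2 to compound 3 (0.35 log units; beyond the scatter). Compound 1 and compound 2 showed only that moving the methoxy matters, whereas this step shows that a second methoxy, ortho to the first, is not merely accepted but gives the stronger inhibitor of growth, on this single example. The steps to compound 3 from both other compounds are beyond the scatter, making it the strongest of the three, and the change from 2-methoxyphenyl to 3,4-dimethoxyphenyl gives an at least 14-fold lower number from compound 1 to compound 3 (1.16 log units; beyond the scatter), a size known only as a lower bound since the value of compound 1 is a limit: the limit of > 10000 nM in this assay, at which 1 of the 3 values shown sits.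

Still open, as far as these compounds go, is whether the step belongs to methoxy itself or would also follow from another group at this place, such as a hydroxyl, a fluorine, a dimethylamino group or the longer ethoxy chain. The compounds shown also do not tell whether the added methoxy needs the methoxy already on the ring.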